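The compounds below may be only part of what the source reports. "The series", "measured", "known", "first", "only" and "open" are said of these compounds alone.

In a functional assay on the whole organism (strain albino) with Mus musculus as the target, at a dose of 100 mg/kg by the intraperitoneal route (a higher number here means more inhibition at the dose given (going by the name of the read-out), a lower number less inhibition), compound 1 , whose structure is `COc1ccc(NC(=O)Nn2c(-c3ccccc3)nc3ccccc3c2=O)cc1`, gives 52%. Compound 2 , with the structure `O=C(Nc1ccc(F)cc1)Nn1c(-c2ccccc2)nc2ccccc2c1=O`, differs from compound 1 in one place: fluoro in place of methoxy on an aromatic carbon. In this assay compound 2 gives 54%, and the step of a number 2 percentage points higher from compound 1 to compound 2 (within the scatter) is a small one. Compound 3 , drawn as `CCc1nc2ccccc2c(=O)n1NC(=O)Nc1ccc(OC)cc1`, keeps the methoxy group of compound 1 but carries a different core; the two cores differ as ethyl in place of phenyl on an aromatic carbon. In this assay compound 3 gives 48%, so the step of a number 4 percentage points lower from compound 1 to compound 3 (within the scatter) is again small, and the three measured numbers sit close together.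

Compound 4 , with the structure `CCc1nc2ccccc2c(=O)n1NC(=O)Nc1ccc(F)cc1`, has not yet been measured. It stands to compound 3 as compound 2 stands to compound 1: the change is fluoro in place of methoxy on an aromatic carbon, the same change, made at the same kind of place on the same kind of ring, only on the core of compound 3 rather than on the core of compound 1. Among these four compounds this change occurs twice, and the one time it has been measured it moved the number by a number 2 percentage points higher from compound 1 to compound 2 (within the scatter). Within the data shown here, the step from compound 3 to compound 4 is therefore expected to be a number 2 percentage points higher from compound 3 to compound 4 (within the scatter), because a number 2 percentage points higher from compound 1 to compound 2 (within the scatter) stayed within the scatter and no other measured example of this change exists here. Compound 4 is accordingly estimated to give 50% in this assay, with a likely range from 38% to 62%.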

Compound 4, a percentage reported as inhibition, in the whole organism at one dose (the size of the read-out at that dose, not a potency): 51%
Compound 4: the middle estimate sits 1 percentage points below what was measured; the measured number falls inside the stated range.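

Read on the core of compound 3, the change from 4-methoxyphenyl to 4-fluorophenyl gives a number 3 percentage points higher from compound 3 to compound 4 (within the scatter), and set beside its earlier reading it comes out alike on both cores: the same change on two cores in this assay, a number 2 percentage points higher (within the scatter) from compound 1 to compound 2 and a number 3 percentage points higher (within the scatter) from compound 3 to compound 4, 1 percentage points apart, within the scatter of two such steps

The other change, ethyl in place of phenyl, can now also be read a second time, with the fluoro group in place, where it gives a number 3 percentage points lower from compound 2 to compound 4 (within the scatter), and it too comes out alike on both cores: the same change on two cores in this assay, a number 4 percentage points lower (within the scatter) from compound 1 to compound 3 and a number 3 percentage points lower (within the scatter) from compound 2 to compound 4, 1 percentage points apart, within the scatter of two such steps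

Among these compounds, all four steps are small enough to sit within the usual spread of repeated measurements, so the agreement shows only that neither change moved the number by a detectable amount on either core in this assay; it does not show that either change has a real effect of its own that carries from one core to another, and it rests on just two cores.

The compounds shown leave open whether a different group in place of the fluoro group, such as an amine or a carboxylic acid, would give a step beyond the scatter. They also leave open whether a longer chain in place of ethyl would do so, and whether any such step would then carry across both cores.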